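The compounds below may be only part of what the source reports. "The series", "measured", "known", "first", "only" and "open" are said of these compounds alone.

Measured compounds:
compound 1, `CN1C/C(=C\c2cccs2)C(=O)[C@@]2(C1)[C@H](c1cccs1)CN(C)[C@]21C(=O)N(C)c2ccccc21`, gives 89.4% in a functional assay on RPMI18226 cells (Homo sapiens) for antiproliferative activity, read by sulforhodamine B assay, with a stated time of 48 h, tested at 10 uM; a lower number here means less inhibition, a higher number more inhibition at the concentration tested (going by the name of the read-out).
compound 2, `Nc1nc(-c2ccccc2)cc(-c2ccc(Cl)cc2)c1C(=O)Nc1ccccc1`, gives 46%.
compound 3, `Cc1ccc(NC(=O)c2c(-c3ccc(Cl)cc3)cc(-c3ccccc3)nc2N)cc1`, gives 71%.

Compound 3 stands second of the three numbers, with compound 1 higher and compound 2 lower, both gaps beyond the scatter. Among the measured compounds shown here, the one step measured, a number 25 percentage points higher from compound 2 to compound 3 (beyond the scatter), comes from a methyl in place of hydrogen on an aromatic carbon and lies beyond the scatter.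

Compound 4, `COc1ccc(Nc2nc(-c3ccccc3)cc(-c3ccc(Cl)cc3)c2C(=O)Nc2ccc(C)cc2)cc1`, is not yet measured. It differs from compound 3 by 4-methoxyphenyl in place of hydrogen on a nitrogen on an aromatic ring; read one bond further out, the amino becomes (4-methoxyphenyl)amino. For the measured compounds named here, no measured step touches this nitrogen, so the methyl step from compound 2 to compound 3 does not bear directly on it. The change is far larger than that methyl step, and its direction cannot be read from the data. A move in either direction beyond the scatter is plausible; the expected step is a number 11 percentage points lower from compound 3 to compound 4 (beyond the scatter), with a wide range. Compound 4 is estimated at 60%, between 25% and 90%.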

Compound 4, a percentage reported as inhibition, at one concentration (the size of the read-out at that concentration, not a potency): 79%
Compound 4: middle estimate off by 19 percentage points, on the low side, within the range that was stated.
By their numbers in this assay, from the lowest: compound 2; then compounds 3 and 4 (each within the scatter of the next); then compound 1.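

The nitrogen on the aromatic ring accepts a 4-methoxyphenyl group, 8 heavy atoms in place of a hydrogen, with a step that stays within the scatter in this assay (a number 8 percentage points higher from compound 3 to compound 4 (within the scatter)). Among the compounds shown here, earlier compounds showed only a methyl change elsewhere in the molecule, so this is the first reading at this nitrogen, and for this pair the unsubstituted amino group is not needed to keep inhibition at this level. No measurement given here explains this outcome.

Still open, as far as these compounds go, is whether a smaller group on this nitrogen, such as methyl or acetyl, or a plain phenyl without the methoxy, gives a similar reading. Also open, from the compounds shown here alone, is whether the 4-methoxyphenyl change reads the same without the methyl of the step (a number 25 percentage points higher from compound 2 to compound 3 (beyond the scatter)), or whether a carboxylic acid in place of the methoxy is accepted.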